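From 1H-indazol-4-yl to 1H-benzimidazol-6-yl

The compounds below may be only part of what the source reports. "The series", "measured", "known", "first", "only" and "open" are said of these compounds alone.

In a physicochemical assay for solubility, read by HPLC, in simulated intestinal fluid, with a stated time of 16 h, tested at 125 ug/mL (on this read-out lower numbers stand for lower solubility and higher numbers for higher solubility), compound 3 `CNC(=O)c1cc(C(=O)NC2CC2)cn(Cc2cccc3[nH]ncc23)c1=O` gives 4 ug/mL, the lowest of the three numbers available. Compound 1 `CNC(=O)c1cc(C(=O)NC2CC2)cn(Cc2cccc3[nH]ccc23)c1=O` gives 17 ug/mL, and compound 2 `CNC(=O)c1cc(C(=O)NC2CC2)cn(Cc2cccc([C@@H](C)O)c2)c1=O` gives 495 ug/mL. Compound 4 `CNC(=O)c1cc(C(=O)NC2CC2)cn(Cc2ccc3nc[nH]c3c2)c1=O` has the same atoms as compound 3, joined differently, with 1H-benzimidazol-6-yl in place of 1H-indazol-4-yl on a saturated chain carbon bound to an aromatic nitrogen.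

Going by the values given here, no measured step tests this exact exchange, but all three measured steps change the group at that same place. The closest is the exchange of 1H-indol-4-yl for 1H-indazol-4-yl, which gave a 4.3-fold lower number from compound 1 to compound 3 (0.63 log units; beyond the scatter). It shows that an exchange between two such similar groups can move the number beyond the scatter in this assay. The exchange of 3-(1-hydroxyethyl)phenyl for 1H-indazol-4-yl gave a 120-fold lower number from compound 2 to compound 3 (2.09 log units; beyond the scatter), which shows how wide the range at this place can be. With compound 3 at the bottom of that range, a rise is more likely than a further fall, and a modest to sizeable one seems reasonable. The expected change is a 7.5-fold higher number from compound 3 to compound 4 (0.88 log units; beyond the scatter). Compound 4 is estimated at 30 ug/mL, with an expected range from 8 ug/mL to 120 ug/mL.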

Compound 4, solubility: 225 ug/mL
Beside the measured number, compound 4's estimate is 7.5-fold (0.88 log units) below it; measured number above the stated range.
By their numbers in this assay, from the lowest: compound 3; then compound 1; then compound 4; then compound 2.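

Compound 3 and compound 4 carry groups with the same atoms and the same counts of rings, donors and acceptors, yet in this assay the change gives a 56-fold higher number from compound 3 to compound 4 (1.75 log units; beyond the scatter), so the way those atoms are joined on a saturated chain carbon bound to an aromatic nitrogen can by itself produce a large step. Until now, the large steps at this place all involved the 3-(1-hydroxyethyl)phenyl group of compound 2, but 1H-benzimidazol-6-yl also gives a 13-fold higher number from compound 1 to compound 4 (1.12 log units; beyond the scatter), a large step between two groups that each have a five-membered and a six-membered aromatic ring, while a 2.2-fold lower number from compound 2 to compound 4 (0.34 log units; beyond the scatter) leaves compound 2 ahead by only a modest step. Nothing measured here accounts for the difference between these groups.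

The exchange alters both where the ring nitrogens stand and which ring atom meets the chain, and the compounds shown do not separate these two changes. They also leave open how the number would respond to an amine or a carboxylic acid carried on 1H-benzimidazol-6-yl.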